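This account rests on a few compounds, and the source may have more. Where it says the series, first, only, none or still open, it means among the compounds named here.

Four compounds share one core. Compound 1 `Cc1ccc2cc(/C=C/C(=O)c3cccc(Br)c3)c(Cl)nc2c1` carries a 3-bromophenyl ketone, and in an ADME assay on MCF7 cells (Homo sapiens) for cytotoxicity, read by MTT assay, with a stated time of 48 h (a lower number here means a stronger inhibitor, a higher number a weaker inhibitor), compound 1 gives "not determined" (no result reported). Compound 2 `C/C(=C\c1cc2cc(C)ccc2nc1Cl)C(=O)c1cccc(Br)c1` carries the same 3-bromophenyl ketone, and in this assay compound 2 gives "not determined" (no result reported). Going by the values given here, compound 3 `Cc1ccc2cc(/C=C/C(=O)c3ccccn3)c(Cl)nc2c1` is the only member with a number: in this assay compound 3 gives 75700 nM, a weak result. Compound 2 thus stands without any value of its own, and the one further entry of that kind, compound 1, is likewise blank. Compound 4 `C/C(=C\c1cc2cc(C)ccc2nc1Cl)C(=O)c1cccc(Cl)c1` differs from compound 2 by chloro in place of bromo on an aromatic carbon. Among the compounds with values here, no measured pair shows this exchange, so its size is unknown; the expectation is a small step in this assay, in no firm direction and likely within the scatter. Compound 4 is estimated at 50000 nM, within 10000 nM to 200000 nM. That expectation rests only on the weak result of compound 3 at 75700 nM.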

Compound 4, half-maximal inhibitory concentration: > 100000 nM
Compound 4: no number, only a limit (the forecaster's own chance of this, stated with the estimate: 30%); at least 2.0-fold (0.30 log units) between middle value and limit.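

Going by these compounds alone, compound 2 has no reported result in this assay, so no step to compound 4 can be read. Compound 4 gives > 100000 nM, which is a limit and not a number. Going by these compounds, what the exchange of bromo for chloro does in this assay remains open.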